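Triazole aryl swap on a fused lactone scaffold

This account rests on a few compounds, and the source may have more. Where it says the series, first, only, none or still open, it means among the compounds named here.

Compound 1 `O=C1O[C@H]([C@@H](O)Cn2cc(-c3cccc(O)c3)nn2)C(OCc2ccccc2)=C1OCc1ccccc1`: 42900 nM
Compound 2 `O=C1O[C@H]([C@@H](O)Cn2cc(-c3cc(F)cc(F)c3)nn2)C(OCc2ccccc2)=C1OCc1ccccc1`: 48200 nM

In a functional assay on HCT-116 cells (Homo sapiens) for antiproliferative activity, read by MTT assay, with a stated time of 72 h (on this read-out higher numbers stand for weaker inhibition and lower numbers for stronger inhibition), compound 2 gives 48200 nM, the higher of the two numbers, while compound 1 gives 42900 nM; the step of a 1.1-fold higher number from compound 1 to compound 2 (0.05 log units; within the scatter) lies within the scatter. Compound 3 `COc1ccc(-c2cn(C[C@H](O)[C@H]3OC(=O)C(OCc4ccccc4)=C3OCc3ccccc3)nn2)cc1` carries 4-methoxyphenyl in place of 3,5-difluorophenyl on an aromatic carbon. Within the data shown here, the only step that bears on this change, a 1.1-fold higher number from compound 1 to compound 2 (0.05 log units; within the scatter), shows that exchanging one aryl group for another left this assay unmoved. The expected step is therefore a 1.1-fold lower number from compound 2 to compound 3 (0.03 log units; within the scatter), with no movement beyond the scatter. Compound 3 is estimated at 45000 nM, within 20000 nM to 100000 nM.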

Compound 3, half-maximal inhibitory concentration: > 100000 nM
Compound 3: a limit, no number; the forecaster's own chance of this, stated with the estimate: 20%; middle value at least 2.2-fold (0.34 log units) from the limit.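

In this assay compound 3 gives > 100000 nM, which is a limit of the assay and not a number. With 4-methoxyphenyl on this aromatic carbon, the data show an at least 2.0-fold higher number from compound 2 to compound 3 (0.31 log units; beyond the scatter) and an at least 2.3-fold higher number from compound 1 to compound 3 (0.36 log units; beyond the scatter). The position therefore does respond to the choice of aryl group, which the earlier step, a 1.1-fold higher number from compound 1 to compound 2 (0.05 log units; within the scatter), had not revealed.

As far as these compounds go, the true size of both new steps stays open, as only their lower bounds can be read. Also open, from the compounds shown here alone, are whether the methoxy group itself or its place on the phenyl ring matters, and how an amine or a carboxylic acid on that phenyl ring would read.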